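Cytotoxicity notes: propylsulfonyl in place of methylpiperazinylcarbonyl

A few compounds are considered here, and "the series" means these few. Any claim that something is new, unique, unknown or untested is made for them only; others in the source may bear on it.

Measured so far:
Compound 1, `COc1cnc(-n2cc(C)cn2)c2[nH]cc(C(=O)C(=O)N3CCN(C(=O)c4ccccc4)CC3)c12`: 243000 nM
Compound 2, `COc1cnc(-n2cnc(C(=O)N3CCN(C)CC3)n2)c2[nH]cc(C(=O)C(=O)N3CCN(C(=O)c4ccccc4)CC3)c12`: > 150000 nM

In a functional assay on MT2 cells (Homo sapiens) for cytotoxicity, read by XTT assay, with a stated time of 3 days (a lower number here means that less compound is tolerated, a higher number that more compound is tolerated), compound 1 gives 243000 nM. For compound 2 the readout is only a limit of the assay, (the limit of > 150000 nM in this assay, at which 1 of the 2 values shown sits), and no number stands for it. Compound 3, `CCCS(=O)(=O)c1ncn(-c2ncc(OC)c3c(C(=O)C(=O)N4CCN(C(=O)c5ccccc5)CC4)c[nH]c23)n1`, differs from compound 2 by propylsulfonyl in place of (4-methylpiperazin-1-yl)carbonyl on an aromatic carbon. Going by the values given here, no step between measured compounds is available, so the effect of this replacement in this assay has no precedent here. Both measured compounds tolerate high concentrations, and compound 3 is expected to do likewise; the step that the limit leaves unreadable from compound 2 to compound 3 is expected to stay within the scatter, with no clear direction. The estimate for compound 3 in this assay is 180000 nM, within 70000 nM to 400000 nM, and a limit rather than a number is a real possibility.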

Compound 3, half-maximal cytotoxic concentration: 207000 nM
Compound 3: middle estimate off by 1.2-fold (0.06 log units), on the low side; measured number inside the range.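

In this assay, compound 3 gives a readable number with propylsulfonyl on the aromatic carbon of the five-membered aromatic ring with 3 nitrogen, so this ring can carry a substituent and still give a value in the same range as the 4-methyl-1H-pyrazol-1-yl group of compound 1. Exchanging that whole group for 3-(propylsulfonyl)-1H-1,2,4-triazol-1-yl gives a 1.2-fold lower number from compound 1 to compound 3 (0.07 log units; within the scatter). Compound 2 stays a limit, so the change from (4-methylpiperazin-1-yl)carbonyl to propylsulfonyl cannot be read as a step: the limit of > 150000 nM in this assay, at which 1 of the 3 values shown sits.

Still open, going by these compounds, is how a primary amine, a carboxylic acid or a longer alkyl chain on this aromatic carbon would read in this assay. On these data alone, the distance between compound 2 and compound 3 also remains unknown.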